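This account rests on a few compounds, and the source may have more. Where it says the series, first, only, none or still open, it means among the compounds named here.

Compound 1 `COc1ccccc1-n1c(Nc2nc(-c3ccccc3)cs2)n[nH]c1=S` gives 100 mg/kg in a functional assay on the whole organism (strain Swiss albino) for inhibition, with Mus musculus as the target, with a stated time of 0.5 h; on this read-out lower numbers stand for an effect already at smaller amounts and higher numbers for an effect only at larger amounts of compound.
Compound 2 `COc1ccccc1-n1c(Nc2nc(-c3ccc(Br)cc3)cs2)n[nH]c1=S` gives 300 mg/kg in this assay.
Compound 3 `Cc1ccccc1-n1c(Nc2nc(-c3ccccc3)cs2)n[nH]c1=S` gives 100 mg/kg in this assay.

Compound 3 stands level with compound 1 at the digits shown, and the two of them give the lowest numbers of the three. The swap of methyl for methoxy gives no change at the digits printed from compound 1 to compound 3 (within the scatter), whereas the added bromine gives a 3.0-fold higher number from compound 1 to compound 2 (0.48 log units; beyond the scatter), a modest rise that lies beyond the scatter.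

Compound 4 `Cc1ccccc1-n1c(Nc2nc(-c3ccc(Br)cc3)cs2)n[nH]c1=S` has not yet been measured. It differs from compound 3 by bromo in place of hydrogen on an aromatic carbon; cut one bond further out, the difference reads phenyl to 4-bromophenyl. Within the data shown here, only one measured step bears on this change, the one from compound 1 to compound 2 with its bromine, which raised the number modestly in this assay. Since compound 3 and compound 1 sit together, the same modest upward step is expected here, a 3.0-fold higher number from compound 3 to compound 4 (0.48 log units; beyond the scatter). Compound 4 is therefore expected to give about 300 mg/kg in this assay, with a range from 150 mg/kg to 600 mg/kg.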

Compound 4, minimum effective dose: 30 mg/kg
Beside the measured number, compound 4's estimate is 10-fold (1.00 log units) above it; the measured number lies below the stated range.
By their numbers in this assay, from the lowest: compound 4; then compounds 1 and 3 (each within the scatter of the next); then compound 2.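

In this assay, bromo in place of hydrogen has no single direction of effect: with methyl instead of methoxy on the core, it gives a 3.3-fold lower number from compound 3 to compound 4 (0.52 log units; beyond the scatter). The same change therefore moves the number in opposite directions on the two cores: the same change on two cores in this assay, a 3.0-fold higher number (0.48 log units; beyond the scatter) from compound 1 to compound 2 and a 3.3-fold lower number (0.52 log units; beyond the scatter) from compound 3 to compound 4, 10-fold (1.00 log units) apart, beyond the scatter of two such steps. The swap of methyl for methoxy, which left the number unchanged without bromine, gives a 10-fold lower number from compound 2 to compound 4 (1.00 log units; beyond the scatter) when the bromo group is present, so its effect also depends on the core: the same change on two cores in this assay, no change at the digits printed (within the scatter) from compound 1 to compound 3 and a 10-fold lower number (1.00 log units; beyond the scatter) from compound 2 to compound 4, 10-fold (1.00 log units) apart, beyond the scatter of two such steps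

From the compounds shown here alone, whether a chloro or an amino group in place of the bromo would also lower the number on the methyl-bearing core remains open, as does whether an ethyl group in place of the methyl would preserve the low number. The compounds shown also do not reveal why the two positions depend on each other.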